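The source may report more compounds than this note shows. Statements on the series, on what has been measured and on what is new or still open speak of the compounds shown alone.

In an assay on frontal cortex for displacement of a labelled ligand from corticotropin-releasing factor receptor 1 (Rattus norvegicus), with a stated time of 2 h (on this read-out lower numbers stand for stronger inhibition and higher numbers for weaker inhibition), compound 1 `CCCCNC(=O)OC[C@H](C1CC1)n1cc(Cl)nc(Nc2cc(C)c(OC)nc2C)c1=O` gives 4.7 nM, and compound 2 `COc1nc(C)c(Nc2nc(Cl)cn([C@H](COc3ccc(C(F)(F)F)cn3)C3CC3)c2=O)cc1C` gives 1.6 nM. Of these two numbers compound 2 has the lower one, with a 2.9-fold lower number from compound 1 to compound 2 (0.47 log units; beyond the scatter). Compound 3 `COc1nc(C)c(Nc2nc(Cl)cn([C@H](COc3cccnc3)C3CC3)c2=O)cc1C` is compound 2 with pyridin-3-yl in place of 5-(trifluoromethyl)pyridin-2-yl on an oxygen on a saturated carbon. Among the measured compounds shown here, the only measured step that touches this same oxygen is a 2.9-fold lower number from compound 1 to compound 2 (0.47 log units; beyond the scatter), which was modest; no measured pair tests the trifluoromethyl group or the point at which the pyridine is joined. For compound 3 the expected change is therefore a 2.5-fold higher number from compound 2 to compound 3 (0.40 log units; beyond the scatter), a small weakening that may well lie within the scatter. The estimate for compound 3 in this assay is 4 nM, with a range from 1.5 nM to 12 nM.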

Compound 3, half-maximal inhibitory concentration: 6.7 nM
For compound 3 the middle estimate is 1.7-fold (0.22 log units) below the measured one, and the stated range covers the measured number.
By their numbers in this assay, from the lowest: compound 2; then compounds 1 and 3 (each within the scatter of the next).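

In this assay the swap on this oxygen brings a 4.2-fold higher number from compound 2 to compound 3 (0.62 log units; beyond the scatter) and so shows that the choice of pyridine group here can move the number beyond the scatter. Replacing butylcarbamoyl with pyridin-3-yl gives a 1.4-fold higher number from compound 1 to compound 3 (0.15 log units; within the scatter) and so a pyridine ring on this oxygen does not by itself give the lower number of compound 2. Nothing measured here explains these differences.

As far as these compounds go, the trifluoromethyl group and the point at which the pyridine is joined changed together, and their separate contributions remain open. Plain pyridin-2-yl on this oxygen would separate the two.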